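A few compounds are considered here, and "the series" means these few. Any claim that something is new, unique, unknown or untested is made for them only; others in the source may bear on it.

Two compounds from this series have so far been run through an ADME assay on the whole organism (plasma, strain Beagle) for pharmacokinetics, with Canis familiaris (Canis lupus familiaris) as the target, read by LC-MS, with a stated time of 8 h, at a dose of 10 mg/kg by the intraduodenal route; on this read-out lower numbers stand for lower exposure and higher numbers for higher exposure at the dose given. Compound 1, `CC(C)C(=O)OCOC(=O)C1=C(S[C@@H]2CN[C@H](C(=O)Nc3cccc(C(=O)OCOC(=O)C(C)C)c3)C2)[C@H](C)[C@@H]2[C@@H]([C@@H](C)O)C(=O)N12`, gives "below limit of detection" (no number reported) in this assay, an entry that carries no single number. Compound 2, `CCOC(=O)C1=C(S[C@@H]2CN[C@H](C(=O)Nc3cccc(C(=O)OCC)c3)C2)[C@H](C)[C@@H]2[C@@H]([C@@H](C)OC(C)=O)C(=O)N12`, gives < 57.4 ng.h/mL in this assay, which is a limit and not a measured number. Going by the values given here, compound 2 therefore cannot be placed on a scale at all: the only information about it is the limit of < 57.4 ng.h/mL in this assay, at which 1 of the 2 values shown sits, and the other reported entry is likewise without a single number, so no measured step within this set exists to lean on.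

Compound 3, `CCOC(=O)C1=C(S[C@@H]2CN[C@H](C(=O)Nc3cccc(C(=O)OCC)c3)C2)[C@H](C)[C@@H]2[C@@H]([C@@H](C)O)C(=O)N12`, differs from compound 2 by hydrogen in place of acetyl on an oxygen on a saturated carbon. Among the compounds with values here, with no measured step to guide the direction, no change beyond the usual scatter is expected for this assay from one compound to the other. Compound 3 is accordingly estimated to give 40 ng.h/mL in this assay, with a likely range from 10 ng.h/mL to 160 ng.h/mL. The step that this estimate implies, a step that the limit leaves unreadable from compound 2 to compound 3, is expected to stay within the scatter of the assay.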

Compound 3, area under the concentration-time curve: 2660 ng.h/mL
For compound 3 the middle estimate is 67-fold (1.82 log units) below the measured one, outside the stated range (above it).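

Going by these compounds alone, until now this series offered no measured step, only entries without a single number, so nothing showed whether the oxygen on the saturated carbon mattered for exposure. In this assay, within the data shown here, replacing acetyl with hydrogen at that place, which turns 1-acetoxyethyl into 1-hydroxyethyl with the rest of the molecule unchanged, gives an at least 46-fold higher number from compound 2 to compound 3 (1.66 log units; beyond the scatter), a large step well beyond the scatter and the first evidence that this position strongly affects the read-out in this pair. Compound 2 enters that step only through a limit and not through a measured number: the limit of < 57.4 ng.h/mL in this assay, at which 1 of the 3 values shown sits.

The compounds shown leave open whether the large step depends on acetyl itself or would also appear with another group on that oxygen, such as propionyl or a methyl ether, or with an amine in place of the hydroxy group. They also leave open whether the same change would produce a similar step with a group other than the ethyl esters carried by this pair, and they do not show why the exposure differs.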